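A few compounds are considered here, and "the series" means these few. Any claim that something is new, unique, unknown or untested is made for them only; others in the source may bear on it.

Working notes on the series. All three measured compounds share one core carrying a dimethylaminophenyl group and a methylpiperazinylphenyl group; they differ only in the group on the ring nitrogen. Compound 1 `CC(=O)N1N=C(c2ccc(N3CCN(C)CC3)cc2)CC1c1ccc(N(C)C)cc1` gives -0.8% in a functional assay on HCC1806 cells (Homo sapiens) for inhibition, read by sulforhodamine B assay, tested at 10 uM; a lower number here means less inhibition, a higher number more inhibition at the concentration tested (going by the name of the read-out). Compound 2 `CN1CCN(c2ccc(C3=NN(C(=O)c4ccc(F)cc4)C(c4ccc(N(C)C)cc4)C3)cc2)CC1` gives 31.8% in this assay, and compound 3 `CN1CCN(c2ccc(C3=NN(S(=O)(=O)c4ccc(C(F)(F)F)cc4)C(c4ccc(N(C)C)cc4)C3)cc2)CC1` gives 27%. Among the measured compounds shown here, the one step between compounds that differ in a single place is a number 32.6 percentage points higher from compound 1 to compound 2 (beyond the scatter), on the carbonyl carbon. Compound 3 stands second highest of the three numbers: its value and that of compound 2 sit within the scatter of each other, while compound 1 sits beyond the scatter below it.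

Compound 4 `CN1CCN(c2ccc(C3=NN(S(=O)(=O)c4ccc(C#N)cc4)C(c4ccc(N(C)C)cc4)C3)cc2)CC1` differs from compound 3 in one place: cyano in place of trifluoromethyl on an aromatic carbon. For the measured compounds named here, no measured step touches this aromatic ring: the step from compound 1 to compound 2 changes the group on the carbonyl carbon, a different place, and the sulfonyl compound 3 has no measured partner of its own. The data therefore give no direction for exchanging trifluoromethyl against cyano on this ring, and the step of a number 2 percentage points lower from compound 3 to compound 4 (within the scatter) is expected to stay within the scatter. Compound 4 is estimated at 25%, between 8% and 42%.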

Compound 4, a percentage reported as inhibition, at one concentration (the size of the read-out at that concentration, not a potency): 99.8%
Compound 4: the middle estimate sits 74.8 percentage points below what was measured, outside the stated range (above it).
By their numbers in this assay, from the lowest: compound 1; then compounds 3 and 2 (each within the scatter of the next); then compound 4.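

Cyano in place of trifluoromethyl on this aromatic carbon gives a number 72.8 percentage points higher from compound 3 to compound 4 (beyond the scatter) in this assay and this shows that, with the sulfonyl group and the rest of compound 3 held fixed, the group on this ring can by itself move the read-out by a large margin, something no earlier step could show. The sulfonyl group alone does not give this result: compound 3 stands within the scatter of compound 2, whereas a number 68 percentage points higher from compound 2 to compound 4 (beyond the scatter) and a number 100.6 percentage points higher from compound 1 to compound 4 (beyond the scatter) set compound 4 clear of both carbonyl compounds, and with the step above it is the highest of the four. No measurement at hand accounts for so large a difference between these two small groups.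

The compounds shown leave open whether cyano would give a similar gain on the fluorophenyl ring of compound 2, and whether a carboxylic acid, an amine or a methoxy group on this aromatic carbon would read like cyano or like trifluoromethyl. With only one tested concentration, they also leave open how the inhibition by compound 4 changes at lower concentrations.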